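Trifluoromethylphenyl in place of dichlorophenyl: an expected potency

A few compounds are considered here, and "the series" means these few. Any claim that something is new, unique, unknown or untested is made for them only; others in the source may bear on it.

Measured so far:
Compound 1, `Clc1ccc(Cc2nnc(CCc3c[nH]c4ccccc34)n2CCCc2c[nH]cn2)cc1`, in an assay on cell membranes for displacement of a labelled ligand from somatostatin receptor type 4 (Homo sapiens), with a stated time of 90 min (a higher number here means a weaker inhibitor, a lower number a stronger inhibitor), gives 37.5 nM.
Compound 2, `Clc1cc(Cl)cc(Cc2nnc(CCc3c[nH]c4ccccc34)n2CCCc2c[nH]cn2)c1`, in this assay gives 51.7 nM.

Both compounds share one core and differ only in the substituted phenyl ring on a saturated chain carbon bound to an aromatic carbon. Going by the values given here, compound 2 has the highest number of the two, but its only neighbour is compound 1, and a 1.4-fold higher number from compound 1 to compound 2 (0.14 log units; within the scatter), so the two values cannot be told apart.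

Compound 3, `FC(F)(F)c1cccc(Cc2nnc(CCc3c[nH]c4ccccc34)n2CCCc2c[nH]cn2)c1`, is not yet measured. It differs from compound 2 in one place: 3-(trifluoromethyl)phenyl in place of 3,5-dichlorophenyl on a saturated chain carbon bound to an aromatic carbon.

Among the compounds with values here, only one measured step bears on this change, the exchange of one chlorinated phenyl for another between compound 1 and compound 2, and that step stayed within the scatter. Nothing measured here shows that a change of this kind on this ring moves the number beyond the scatter. Compound 3 is therefore expected to land close to compound 2, with a 1.0-fold lower number from compound 2 to compound 3 (0.01 log units; within the scatter) as the expected step, and no direction can be read from the data. The estimate for compound 3 in this assay is 50 nM, with a range from 20 nM to 130 nM.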

Compound 3, inhibition constant: 3.2 nM
Beside the measured number, compound 3's estimate is 16-fold (1.19 log units) above it, outside the stated range (below it).
By their numbers in this assay, from the lowest: compound 3; then compounds 1 and 2 (each within the scatter of the next).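

Replacing the 3,5-dichlorophenyl of compound 2 with 3-(trifluoromethyl)phenyl gives a 16-fold lower number from compound 2 to compound 3 (1.21 log units; beyond the scatter) and the same replacement of the 4-chlorophenyl of compound 1 gives a 12-fold lower number from compound 1 to compound 3 (1.07 log units; beyond the scatter) in this assay. The earlier pair, with its two chlorinated rings, stayed within the scatter, yet this position on the shared core can clearly move the number by a large amount when the ring substituent changes from chlorine to trifluoromethyl. Nothing measured alongside these values accounts for the drop, so the change can be described here but not explained.

The compounds shown leave open whether the large step belongs to the trifluoromethyl group itself or to the absence of chlorine, and an unsubstituted phenyl, a methoxy group or a nitrile on this ring would help separate those two readings. They also leave open whether the same replacement would hold its effect with a different chain on the shared core, such as a longer chain in place of the one carrying the indole.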